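The source may report more compounds than this note shows. Statements on the series, on what has been measured and on what is new or still open speak of the compounds shown alone.

Measured compounds:
Compound 1, `Cc1cc(C)c(Oc2cc(Nc3ccc(C#N)cc3)c(N)cc2[N+](=O)[O-])c(C)c1`, in an ADME assay on H9 cells (Homo sapiens) for cytotoxicity, read by XTT assay, with a stated time of 6 days (on this read-out higher numbers stand for lower toxicity in this test and lower numbers for higher toxicity in this test), gives 32200 nM.
Compound 2, `Cc1cc(C)c(Oc2cc(Nc3ccc(C#N)cc3)c([N+](=O)[O-])cc2[N+](=O)[O-])c(C)c1`, in this assay gives only a limit of the assay, > 59800 nM.
Compound 3, `Cc1cc(Br)cc(C)c1Oc1ccc([N+](=O)[O-])c(Nc2ccc(C#N)cc2)c1`, in this assay gives only a limit of the assay, > 57000 nM.

One structural change appears twice among these compounds. From compound 2 to compound 1 it is amino in place of nitro on an aromatic carbon, and in this assay it made the step of an at least 1.8-fold lower number from compound 2 to compound 1 (0.26 log units; that floor lies within the scatter). This step is a floor only, since compound 2 sits at the limit of > 59800 nM in this assay, at which 1 of the 3 values shown sits. How the core of compound 2 differs from the core of compound 3 is not broken down here.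

Compound 4, `Cc1cc(Br)cc(C)c1Oc1ccc(N)c(Nc2ccc(C#N)cc2)c1`, has not yet been measured in this assay. It comes from compound 3 by amino in place of nitro on an aromatic carbon. The surroundings of the changed carbon are not identical in the two pairs: in compound 2 the carbon is also meta to a nitro group and para to a 2,4,6-trimethylphenoxy group, whereas in compound 3 it is para to a large group. The two changes are therefore the same kind of change, not the same change.

Compound 3 sits at the limit of > 57000 nM in this assay, at which 1 of the 3 values shown sits, so its own value gives only a floor. The step from compound 3 to compound 4 is expected to be an at least 1.6-fold lower number from compound 3 to compound 4 (0.21 log units; that floor lies within the scatter), which rests on the measured step of an at least 1.8-fold lower number from compound 2 to compound 1 (0.26 log units; that floor lies within the scatter) and on the value of compound 1, 32200 nM. Compound 4 is estimated at about 35000 nM in this assay. Compound 4 is expected to fall between 15000 nM and 70000 nM.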

Compound 4, half-maximal cytotoxic concentration: 44600 nM
Estimate against measurement, compound 4: 1.3-fold (0.11 log units) below, within the range that was stated.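

In this assay, amino in place of nitro gives an at least 1.2-fold lower number from compound 3 to compound 4 (0.10 log units; that floor lies within the scatter), and this floor, like the earlier one, does not pass the usual scatter. Set beside the earlier case, the change can be followed on two cores, but no size can be carried from one core to the other: the same change on two cores in this assay, an at least 1.8-fold lower number (0.26 log units; that floor lies within the scatter) from compound 2 to compound 1 and an at least 1.2-fold lower number (0.10 log units; that floor lies within the scatter) from compound 3 to compound 4; the limit leaves it open whether they differ In each pair the amino compound has a measured value and the nitro compound only a limit of the assay, so the pairs do not show that the change lowers the number by a similar amount on both cores, or by more than the scatter on either.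

The compounds shown leave open the real distance between each nitro compound and its amino partner, and whether the same change would read alike on further cores. Also open, on these data alone, is how other groups on the same carbon would read in this assay, such as a methylamino group, an acetamide or a carboxylic acid.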